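A few compounds are considered here, and "the series" means these few. Any claim that something is new, unique, unknown or untested is made for them only; others in the source may bear on it.

Measured so far:
compound 1 `CCCn1c(=O)[nH]c2nc(-c3ccc(S(=O)(=O)N4CCN(C)CC4)cc3)[nH]c2c1=O` — 334 nM
compound 2 `CCCn1c(=O)[nH]c2nc(-c3ccc(S(=O)(=O)N4CCN(c5ccc(C)cc5)CC4)cc3)[nH]c2c1=O` — a limit of the assay, > 1000 nM

In an assay on CHO cells for displacement of a labelled ligand from adenosine receptor A1 (Homo sapiens), read by scintillation counting, with a stated time of 90 min, in the presence of a further agent that is not named here (on this read-out higher numbers stand for weaker inhibition and lower numbers for stronger inhibition), compound 1 gives 334 nM. For compound 2 this assay records only a limit, > 1000 nM. Compound 2 therefore stands at the weak end of the numbers shown, without an exact figure. Within the data shown here, the single measured step, an at least 2.9-fold higher number from compound 1 to compound 2 (0.47 log units; beyond the scatter), places it there; its full size is open because one value sits at the limit of > 1000 nM in this assay, at which 1 of the 2 values shown sits.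

Compound 3 `CCCn1c(=O)[nH]c2nc(-c3ccc(S(=O)(=O)N4CCN(c5ccc(I)cc5)CC4)cc3)[nH]c2c1=O` is not yet measured in this assay. It differs from compound 2 by iodo in place of methyl on an aromatic carbon. Among the measured compounds shown here, no measured step covers a change on that outer aromatic ring: the only recorded step, an at least 2.9-fold higher number from compound 1 to compound 2 (0.47 log units; beyond the scatter), concerns what sits on the amine nitrogen of the ring and says nothing about a methyl-to-iodo swap further out. On the present numbers no step beyond the scatter is expected, so compound 3 is expected to give a step that the limit leaves unreadable from compound 2 to compound 3. Compound 3 is estimated at 2500 nM, most likely again reported only as a limit, with a range from 800 nM to 8000 nM.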

Compound 3, inhibition constant: > 1000 nM
Compound 3 gave a limit, no number (the forecaster's own chance of this, stated with the estimate: 70%); the middle value is on the limit's open side.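

Like compound 2, compound 3 is recorded in this assay only as a limit, > 1000 nM. The change from methyl to 4-iodophenyl on the amine nitrogen in the ring gives an at least 2.9-fold higher number from compound 1 to compound 3 (0.47 log units; beyond the scatter), so the loss seen with 4-methylphenyl also appears with a second group on the outer phenyl ring, and both compounds with a substituted phenyl on that nitrogen go against nothing in this small set. The step from compound 2 to compound 3 cannot be read, because both compounds sit at the same limit and the swap of methyl for iodo on the aromatic carbon therefore remains unresolved: the limit of > 1000 nM in this assay, at which 2 of the 3 values shown sit.

Going by these compounds, the true strengths of compound 2 and compound 3 stay unknown, so it remains open whether the methyl-to-iodo change matters at all on this read-out. Also open, on these data alone, is where along the way from methyl to a substituted phenyl the numbers rise, for example with an ethyl chain, a benzyl group or an unsubstituted phenyl on the amine nitrogen, and whether a hydrogen there would give a lower number than compound 1.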